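The source may report more compounds than this note shows. Statements on the series, on what has been measured and on what is new or still open speak of the compounds shown alone.

compound 1 `Oc1cc(C(F)(F)F)ccc1-c1nc(-c2ccccc2O)n(-c2ccc(F)cc2)n1`: 67.2%
compound 2 `COc1ccccc1-n1nc(-c2ccc(C(F)(F)F)cc2O)nc1-c1ccccc1O`: 70.7%

In a functional assay on PC-12 cells (Rattus norvegicus) for cytotoxicity, read by MTT assay, with stated times of 2 h and 24 h, tested at 1 uM (a lower number here means a weaker effect, a higher number a stronger effect of the compound at the concentration tested), compound 1 gives 67.2% and compound 2 gives 70.7%. Among the compounds with values here, compound 2 heads the two numbers, yet its only neighbour is compound 1, and the step of a number 3.5 percentage points higher from compound 1 to compound 2 (within the scatter) is within the scatter. Compound 3 `Oc1cc(C(F)(F)F)ccc1-c1nc(-c2ccccc2O)n(-c2cccc(F)c2)n1` differs from compound 2 by 3-fluorophenyl in place of 2-methoxyphenyl on an aromatic nitrogen. Within the data shown here, the one measured step bearing on this change, a number 3.5 percentage points higher from compound 1 to compound 2 (within the scatter), also swapped the group on that aromatic nitrogen without effect beyond the scatter, so in this assay the expected step is a number 1.7 percentage points lower from compound 2 to compound 3 (within the scatter), none beyond the scatter. Compound 3 is estimated at 69%, between 58% and 80%.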

Compound 3, a percentage reported as activity, at one concentration (the size of the read-out at that concentration, not a potency): 67.2%
Compound 3: middle estimate off by 1.8 percentage points, on the high side; the range from low to high includes it.
By their numbers in this assay, from the lowest: compounds 1, 3 and 2 (each within the scatter of the next).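

In this assay the swap to 3-fluorophenyl gives a number 3.5 percentage points lower from compound 2 to compound 3 (within the scatter) and, against the 4-fluorophenyl group, no change at the digits printed from compound 1 to compound 3 (within the scatter). Three different aryl groups on this aromatic nitrogen, including two placements of the fluorine, now stay within the scatter of one another at the single concentration tested. No evidence is available that would account for this. The compounds shown leave open whether a non-aryl group on that nitrogen, such as a chain bearing an amine or a carboxylic acid, would separate from these three.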